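A few compounds are considered here, and "the series" means these few. Any claim that something is new, unique, unknown or untested is made for them only; others in the source may bear on it.

Compound 1 `COC(=O)c1cc(OCC(=O)[C@H](CC(=O)O)NC(=O)[C@@H](NC(=O)COc2cccc3ccccc23)C(C)C)no1` opens the series; in a functional assay on Jurkat cells (Homo sapiens) for inhibition (on this read-out lower numbers stand for stronger inhibition and higher numbers for weaker inhibition), compound 1 gives 71000 nM. Compound 2 `CC(C)[C@H](NC(=O)COc1cccc2ccccc12)C(=O)N[C@@H](CC(=O)O)C(=O)CSc1nccn1C` carries (1-methyl-1H-imidazol-2-yl)sulfanyl in place of (5-(methoxycarbonyl)-1,2-oxazol-3-yl)oxy on a saturated chain carbon bound to a carbonyl carbon. In this assay compound 2 reaches only the limit > 200000 nM, so no number is known for it. Going by the values given here, the step of an at least 2.8-fold higher number from compound 1 to compound 2 (0.44 log units; beyond the scatter) is therefore bounded by the limit of > 200000 nM in this assay, at which 1 of the 2 values shown sits, and this is the only step measured. Compound 3 `CC(C)[C@H](NC(=O)COc1cccc2ccccc12)C(=O)N[C@@H](CC(=O)O)C(=O)CSC1=NCCS1` differs from compound 2 by a group of 5 heavy atoms (3 carbon, 1 nitrogen, 1 sulfur; one five-membered non-aromatic ring with 2 hetero atoms) in place of a group of 6 heavy atoms (4 carbon, 2 nitrogen; one five-membered aromatic ring with 2 hetero atoms), on a sulfur. Among the compounds with values here, no measured step touches this change, and the one step known concerns a different group, so it offers no direction here. Compound 3 is therefore expected near 200000 nM, with a range from 60000 nM to 600000 nM, the step from compound 2 being estimated as a number no higher from compound 2 to compound 3 (the limit leaves the size open).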

Compound 3, half-maximal inhibitory concentration: > 200000 nM
Compound 3: a limit, no number; the forecaster's own chance of this, stated with the estimate: 60%; the middle value lies on the limit itself.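

Replacing 1-methyl-1H-imidazol-2-yl on the sulfur with a five-membered non-aromatic ring with 2 hetero atoms does not bring a measurable number in this assay: compound 3 stays at > 200000 nM, which is a limit and not a number. The step between compound 2 and compound 3 cannot be read, because both compounds sit at a limit: the limit of > 200000 nM in this assay, at which 2 of the 3 values shown sit. Measured against compound 1, the change of the whole group gives an at least 2.8-fold higher number from compound 1 to compound 3 (0.44 log units; beyond the scatter), so two different sulfur-linked rings now lie on the weaker side of compound 1.

On these data alone, how far compound 2 and compound 3 lie past the limit remains open, and so does any order between them. The compounds shown also do not tell whether a phenoxy group or a fluorine on this saturated chain carbon would give stronger inhibition than compound 1.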